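The source may report more compounds than this note shows. Statements on the series, on what has been measured and on what is new or still open speak of the compounds shown alone.

Compound 1, `OC1CCCc2nc(-c3ccc(N4CCCC4)cc3)sc21`, was tested in a functional assay on MCF7 cells (Homo sapiens) for cytotoxicity, read by sulforhodamine B assay, with a stated time of 2 days (a higher number here means a weaker inhibitor, a lower number a stronger inhibitor), where it gives 8700 nM. That is the highest of the two numbers recorded here. The nearest neighbour is compound 2, `Cc1cc(N(C)C)ccc1-c1nc2c(s1)[C@@H](O)CCC2`, which in this assay gives 2150 nM, a lower number that lies beyond the usual scatter; the two compounds differ in more than one place, so the values alone cannot be traced to a single change.

Compound 3, `OCc1cc(N2CCCC2)ccc1-c1nc2c(s1)C(O)CCC2`, has not yet been measured. It differs from compound 1 in one place: hydroxymethyl in place of hydrogen on an aromatic carbon. A single hydroxymethyl group added to a ring carbon of the shared core is a small change on a compound that is already a weak inhibitor. Among the measured compounds shown here, with no comparable step recorded among the measured compounds, the expectation is a step from compound 1 to compound 3 of a 1.3-fold lower number from compound 1 to compound 3 (0.13 log units; within the scatter), which could fall either way and might not exceed the scatter. Compound 3 is therefore estimated to give about 6500 nM in this assay, within a range from 2000 nM to 20000 nM.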

Compound 3, half-maximal inhibitory concentration: 56 nM
The estimate for compound 3 lay 120-fold (2.06 log units) above the measured number, and the stated range ends above it.
By their numbers in this assay, from the lowest: compound 3; then compound 2; then compound 1.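

In this assay, putting hydroxymethyl in place of hydrogen on an aromatic carbon gives a 160-fold lower number from compound 1 to compound 3 (2.19 log units; beyond the scatter), a large step for so small a group. This shows that the place ortho to a large group and meta to a pyrrolidin-1-yl group is far from indifferent to what it carries, which compound 1 and compound 2 could not show, as they differ in more than one place. Nothing among the data shown bears on the cause of this step.

Among the compounds shown here, the single step cannot tell whether the gain belongs to the hydroxymethyl group in particular or would come with other small groups on this aromatic carbon, so an aminomethyl group, a methoxymethyl group or a carboxylic acid in the same place would be needed to separate those readings. As far as these compounds go, it also remains open how the number would respond to a longer chain there, such as hydroxyethyl, and whether hydroxymethyl would give a step of this size on a compound with a different group in place of pyrrolidin-1-yl.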